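Chloro for methoxy on the acid analogue of compound 3

A few compounds are considered here, and "the series" means these few. Any claim that something is new, unique, unknown or untested is made for them only; others in the source may bear on it.

Measured compounds:
- compound 1 `COC(=O)c1c(Nc2ccc(OC)cc2)sc(C(=O)c2ccc(OC)cc2)c1C`: 4.29%
- compound 2 `COC(=O)c1c(Nc2ccc(Cl)cc2)sc(C(=O)c2ccc(OC)cc2)c1C`: "not active" (no number reported)
- compound 3 `COc1ccc(Nc2sc(C(=O)c3ccc(OC)cc3)c(C)c2C(=O)O)cc1`: 20.2%

In a functional assay, with a stated time of 150 min, tested at 5 ug/mL (on this read-out lower numbers stand for a weaker effect and higher numbers for a stronger effect at the one concentration tested), compound 3 gives the highest of the two numbers reported; compound 1 sits a number 15.9 percentage points higher from compound 1 to compound 3 (beyond the scatter), and compound 2 returned no number at all. The unmeasured compound 4 `COc1ccc(C(=O)c2sc(Nc3ccc(Cl)cc3)c(C(=O)O)c2C)cc1` is compound 3 with a single change: chloro in place of methoxy on an aromatic carbon.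

Among the compounds with values here, no measured step covers exactly this change on compound 3. The closest guide is the pair of esters: compound 1 carries the methoxy and gives 4.29%, while compound 2 carries the chloro and is reported as "not active" (no number reported). That pair suggests the swap does not help and may remove what little effect there is. Compound 3 itself stands above compound 1 by the step from the methyl ester to the acid, which may keep compound 4 from falling to nothing. The expected outcome is therefore a drop, a number 15.2 percentage points lower from compound 3 to compound 4 (beyond the scatter), with a fair chance of no number at all. Compound 4 is estimated at 5%, with a range from 0% to 15%.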

Compound 4, a percentage reported as activity, at one concentration (the size of the read-out at that concentration, not a potency): "not active" (no number reported)
The entry for compound 4 holds no number; no gap can be computed for the estimate.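

In this assay, within the data shown here, compound 4 is reported as "not active" (no number reported), so no step from compound 3 can be read, and no evidence bears on this result. The compounds shown leave open how large the real gap between compound 3 and compound 4 is.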